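Moving a Fluorine Around the Benzyl Ring

A few compounds are considered here, and "the series" means these few. Any claim that something is new, unique, unknown or untested is made for them only; others in the source may bear on it.

In a functional assay on HUVEC cells (Homo sapiens) for antiproliferative activity, read by MTT assay, with a stated time of 24 h (a higher number here means a weaker inhibitor, a lower number a stronger inhibitor), compound 1 `COc1cc(OC)c(-c2coc3cc(OCc4ccccc4)ccc3c2=O)cc1OC` gives 9750 nM while compound 2 `COc1cc(OC)c(-c2coc3cc(OCc4ccccc4F)ccc3c2=O)cc1OC` stands lowest of the two, with 4300 nM as its number. Compound 3 `COc1cc(OC)c(-c2coc3cc(OCc4ccc(F)cc4)ccc3c2=O)cc1OC` has the same atoms joined differently, with 4-fluorophenyl in place of 2-fluorophenyl on a saturated chain carbon bound to an oxygen on an aromatic ring. For the measured compounds named here, only one measured step bears on this change: putting fluoro in place of hydrogen on an aromatic carbon gave a modest shift (a 2.3-fold lower number from compound 1 to compound 2 (0.36 log units; beyond the scatter)). Going by the values given here, no measured pair shows what moving the fluorine does, so that step sets only a rough scale. In this assay a smaller step is therefore expected, probably within the scatter and slightly towards a higher number (a 1.2-fold higher number from compound 2 to compound 3 (0.07 log units; within the scatter)). Compound 3 is estimated to read 5000 nM (expected range 2400 nM to 10000 nM).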

Compound 3, half-maximal inhibitory concentration: > 10000 nM
Compound 3 was reported as a limit; the forecaster's own chance of this, stated with the estimate: 5%; middle value at least 2.0-fold (0.30 log units) from the limit.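

Where the fluorine sits on the benzyl ring matters in this assay: with the same atoms joined differently, 4-fluorophenyl in place of 2-fluorophenyl gives an at least 2.3-fold higher number from compound 2 to compound 3 (0.36 log units; beyond the scatter) and cancels the gain seen earlier. Fluoro in place of hydrogen is therefore not enough on its own, since the other comparison gives only an at least 1.0-fold higher number from compound 1 to compound 3 (0.01 log units; that floor lies within the scatter) and compound 3 cannot be told apart from compound 1 on that floor. (For compound 3 the reading > 10000 nM is a limit and not a number: the limit of > 10000 nM in this assay, at which 1 of the 3 values shown sits).

As far as these compounds go, whether chloro or methyl in the place of the fluorine in 2-fluorobenzyl would keep or extend the gain stays open. So does how a longer chain in place of the benzyl link would read.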